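Removing the nitro group from compound 2: an expected small shift

This account rests on a few compounds, and the source may have more. Where it says the series, first, only, none or still open, it means among the compounds named here.

Of the compounds shown here, three of one shared core have been measured in an ADME assay on L6 cells (Rattus norvegicus) for cytotoxicity, read by sulforhodamine B assay, with a stated time of 72 h; on this read-out higher numbers stand for weaker inhibition and lower numbers for stronger inhibition. Compound 1 `O=C1C(Nc2ccccc2C(F)(F)F)=C(Nc2ccccc2C(F)(F)F)C(=O)c2c1cccc2[N+](=O)[O-]` gives 88000 nM. Compound 2 `Cc1ccccc1NC1=C(Nc2ccccc2C)C(=O)c2c(cccc2[N+](=O)[O-])C1=O` gives 186000 nM, and compound 3 `O=C1C(Nc2ccc(C(F)(F)F)cc2)=C(Nc2ccc(C(F)(F)F)cc2)C(=O)c2ccccc21` gives 276000 nM. Compound 2 thus stands second highest of the three numbers. Its nearest neighbour is compound 3, whose number is higher by an amount within the usual scatter, so the two cannot be ordered. Compound 1 is the furthest, with a number lower than that of compound 2 by an amount beyond the scatter.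

Compound 4 `Cc1ccccc1NC1=C(Nc2ccccc2C)C(=O)c2ccccc2C1=O` has not yet been measured. It differs from compound 2 in one place: hydrogen in place of nitro on an aromatic carbon. For the measured compounds named here, no pair of measured compounds differs by exactly this change, so no measured step can be used as a direct guide. Going by the values given here, compound 3, which also carries no nitro group, sits close to compound 2 in this assay, but its other groups differ too, so it shows only that a core without the nitro group can give numbers of the same size.

The step from compound 2 to compound 4 in this assay is therefore expected to be small, likely toward a higher number, as a 1.2-fold higher number from compound 2 to compound 4 (0.09 log units; within the scatter). Compound 4 is expected to give about 230000 nM, within a range from 110000 nM to 450000 nM.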

Compound 4, half-maximal inhibitory concentration: > 450000 nM
Compound 4: a limit, no number; the forecaster's own chance of this, stated with the estimate: 15%; at least 1.9-fold (0.29 log units) between middle value and limit.
By their numbers in this assay, from the lowest: compound 1; then compounds 2 and 3 (each within the scatter of the next). At a limit, above all of these: compound 4.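

In this assay, compound 4 gives > 450000 nM, which is a limit of the assay and not a number. For the compounds shown here, putting hydrogen in place of nitro on this aromatic carbon, ortho to a fused ring and meta to a fused ring, gives an at least 2.4-fold higher number from compound 2 to compound 4 (0.38 log units; beyond the scatter), so this pair shows that the change moves the read-out beyond the scatter, toward weaker inhibition, something none of the earlier compounds could show, since no earlier pair differed in one place alone. Only the smallest possible size of this step can be read, and its full size stays unknown, because the result for compound 4 lies at the limit: the limit of > 450000 nM in this assay, at which 1 of the 4 values shown sits.

This single pair leaves open whether the same change would give a step of similar size with other groups on the two aromatic amine arms, such as the trifluoromethyl groups of compound 1. It also leaves open whether an amine, a nitrile or a carboxylic acid on the same aromatic carbon would keep the read-out close to that of compound 2 or shift it as hydrogen does.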